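Diaryl urea series: cytotoxicity limits and a demethylation step

The compounds below may be only part of what the source reports. "The series", "measured", "known", "first", "only" and "open" are said of these compounds alone.

Measured compounds, with the limit each reached in a functional assay on NCI-H226 cells (Homo sapiens) for inhibition, read by sulforhodamine B assay, with a stated time of 48 h; a lower number here means that less compound is tolerated, a higher number that more compound is tolerated:
- compound 1 `O=C(Nc1cccc(-n2cc(-c3ccncc3)c(-c3ccc(Cl)c(O)c3)n2)c1)Nc1cccc(C(F)(F)F)c1`: compound 1 gives > 32500 nM, a limit of the assay.
- compound 2 `O=C(Nc1cccc(-n2cc(-c3ccncc3)c(-c3ccc(Cl)c(O)c3)n2)c1)Nc1ccc(Cl)c(Cl)c1`: compound 2 gives > 32500 nM, a limit of the assay.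
- compound 3 `COc1cc(-c2nn(-c3cccc(NC(=O)Nc4ccc(Cl)c(C(F)(F)F)c4)c3)cc2-c2ccncc2)ccc1Cl`: compound 3 gives > 32500 nM, a limit of the assay.

Compound 3 thus stands at the limit, as do all three values shown (the limit of > 32500 nM in this assay, at which 3 of the 3 values shown sit). Among the measured compounds shown here, the only single-point step among them, a step that the two limits leave unreadable from compound 1 to compound 2, is unreadable between two limits. Compound 4 `O=C(Nc1cccc(-n2cc(-c3ccncc3)c(-c3ccc(Cl)c(O)c3)n2)c1)Nc1ccc(Cl)c(C(F)(F)F)c1` differs from compound 3 by hydrogen in place of methyl on an oxygen on an aromatic ring. No measured step touches this oxygen, so nothing shown predicts a readable shift; the step that the limit leaves unreadable from compound 3 to compound 4 is expected to stay within the scatter. Compound 4 is therefore expected again at the limit, estimated near 40000 nM with a range from 15000 nM to 100000 nM.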

Compound 4, concentration lethal to 50% of the cells: > 32500 nM
Compound 4: a limit, no number (the forecaster's own chance of this, stated with the estimate: 80%); the middle value does not contradict the limit.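

No step among compound 1, compound 2, compound 3 and compound 4 can be read, since each value is a limit: the limit of > 32500 nM in this assay, at which 4 of the 4 values shown sit.

The compounds shown leave open whether any of these changes, including methoxy to hydroxy, shifts the result in this assay.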